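This account rests on a few compounds, and the source may have more. Where it says the series, first, only, none or still open, it means among the compounds named here.

In an ADME assay (liver) for metabolic stability, with Liver microsome (Rattus norvegicus) as the target, using microsomes and NADPH, with a stated time of 30 min (a lower number here means slower removal, a higher number faster removal of the compound), compound 1 `CC#C[C@H]1CN(S(=O)(=O)c2ccc(N)nc2)CCN1c1ccccc1` gives > 399 mL.min-1.g-1, which is a limit of the assay and not a number. Compound 2 `CC#C[C@H]1CN(S(=O)(=O)c2ccc(N)nc2)CCN1c1ccc(S(=O)(=NC)C(F)(F)F)cc1` gives 257 mL.min-1.g-1, the higher of the two true numbers in this set, and compound 3 `CC#C[C@H]1CN(S(=O)(=O)c2ccc(N)nc2)CCN1c1ccc(C(C)(O)C(F)(F)F)nc1` gives 31 mL.min-1.g-1, a gap beyond the scatter. Compound 4 `CC#C[C@H]1CN(S(=O)(=O)c2ccc(N)nc2)CCN1c1ccc(S(=O)(=O)NCC2CC2)cc1` departs from compound 2 in one place: a group of 8 heavy atoms (4 carbon, 1 nitrogen, 2 oxygen, 1 sulfur; one three-membered non-aromatic ring of carbon only) in place of a group of 8 heavy atoms (2 carbon, 1 nitrogen, 1 oxygen, 3 fluorine, 1 sulfur; no ring), on an aromatic carbon. Going by the values given here, the one measured step at this place is an at least 1.5-fold lower number from compound 1 to compound 2 (0.19 log units; that floor lies within the scatter), and it is only a floor because of the limit of > 399 mL.min-1.g-1 in this assay, at which 1 of the 3 values shown sits. Among the compounds with values here, that step brings in the group that compound 4 gives up, but no measured step exchanges one such group for another, so the data show no direction for this change. The expectation therefore stays close to compound 2 at 257 mL.min-1.g-1. The expected step is a 1.3-fold lower number from compound 2 to compound 4 (0.11 log units; within the scatter), with no change beyond the scatter anticipated. For compound 4 the estimate is 200 mL.min-1.g-1, with an expected range from 80 mL.min-1.g-1 to 390 mL.min-1.g-1.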

Compound 4, intrinsic clearance in microsomes: 213 mL.min-1.g-1
Compound 4: middle estimate off by 1.1-fold (0.03 log units), on the low side; measured number inside the range.
By their numbers in this assay, from the lowest: compound 3; then compounds 4 and 2 (each within the scatter of the next). At a limit, above all of these: compound 1.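

In this assay, the exchange on this aromatic carbon, para to a large group, gives a 1.2-fold lower number from compound 2 to compound 4 (0.08 log units; within the scatter). Going by these compounds alone, this is the first measured exchange of one such group for another at this position, and it shows no change beyond the scatter, even though (cyclopropylmethyl)sulfamoyl brings a hydrogen-bond donor and a three-membered ring of carbon only. In place of hydrogen, the same group gives an at least 1.8-fold lower number from compound 1 to compound 4 (0.27 log units; that floor lies within the scatter), and this step, like the earlier one, is only a floor because compound 1 stands at a limit of the assay: the limit of > 399 mL.min-1.g-1 in this assay, at which 1 of the 4 values shown sits.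

As far as these compounds go, the true size of the step from hydrogen to either group therefore stays open. From the compounds shown here alone, it is also open whether a carboxylic acid, an amine or a longer chain on the sulfamoyl nitrogen at this place would move the number beyond the scatter.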